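Pentyl for isopropyl: next step in the series

The source may report more compounds than this note shows. Statements on the series, on what has been measured and on what is new or still open speak of the compounds shown alone.

Compound 1 `CC(C)c1ccc(NC(=O)N[C@H](C)c2ccccc2)cc1` and compound 2 `CC(C)c1ccc(NC(=O)N[C@@H](C)c2ccccc2)cc1` share all atoms and bonds and differ only in configuration as drawn. In an ADME assay on the whole organism with Oryza sativa as the target, tested at 10 uM (on this read-out higher numbers stand for a weaker effect at the one concentration tested and lower numbers for a stronger effect), compound 1 gives 49% and compound 2 gives 86%; the step of a number 37 percentage points higher from compound 1 to compound 2 (beyond the scatter) is the only measured one, and the fact that compounds 1 and 2 differ only in the configuration as drawn is all that stands behind it. Compound 2 thus holds the higher of the two numbers in this assay.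

Compound 3 `CCCCCc1ccc(NC(=O)N[C@@H](C)c2ccccc2)cc1` departs from compound 2 by pentyl in place of isopropyl on an aromatic carbon. Among the compounds with values here, no measured step touches an alkyl group on the aromatic ring: the one step known, a number 37 percentage points higher from compound 1 to compound 2 (beyond the scatter), concerns configuration alone and says nothing about pentyl in place of isopropyl. The expectation is therefore no step beyond the scatter in this assay, so a number 2 percentage points lower from compound 2 to compound 3 (within the scatter) is the estimated change. Compound 3 is expected to give about 84% in this assay, within 62% to 100%.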

Compound 3, a percentage reported as activity, at one concentration (the size of the read-out at that concentration, not a potency): 93%
Compound 3: the middle estimate sits 9 percentage points below what was measured; the range from low to high includes it.
By their numbers in this assay, from the lowest: compound 1; then compounds 2 and 3 (each within the scatter of the next).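

In this assay, pentyl in place of isopropyl on the aromatic carbon para to a large group gives a number 7 percentage points higher from compound 2 to compound 3 (within the scatter) and so leaves the reading at this position within the scatter, with the configuration of compound 2 kept. Within the data shown here, the only earlier step concerned configuration alone, so this is the first reading of a change in the alkyl group itself, and within this single pair, the longer chain brings no step beyond the scatter. Nothing on hand bears on what lies behind this step.

Going by these compounds, whether an amine, a carboxylic acid or a chain longer than pentyl at this position would read the same remains open. Also open, on these data alone, is how pentyl reads with the configuration of compound 1, the one that gave the lower number.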